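The source may hold more compounds than are shown below. What is called first, only, known or untested is meant among the compounds shown, and "the series" means these compounds.

Measured compounds in an assay on U2OS cells for activation of nuclear factor erythroid 2-related factor 2 (Homo sapiens), read by beta-arrestin recruitment, with a stated time of 6 h; a higher number here means that more compound is needed for the effect, a lower number that less compound is needed:

compound 1 `O=S(=O)(/C=C/c1ccccn1)c1ccccc1F` gives 1050 nM
compound 2 `O=S(=O)(/C=C/c1ccc(Cl)cn1)c1ccccc1F` gives 1040 nM
compound 3 `O=S(=O)(/C=C/c1ccccn1)c1cccc(F)c1` gives 1680 nM

Compound 1 and compound 2 share a core and differ by chloro in place of hydrogen on an aromatic carbon. That change made the step of a 1.0-fold lower number from compound 1 to compound 2 (0.00 log units; within the scatter). Compound 3 has the same atoms as compound 1 joined differently; the difference between the two cores is not broken down here. In this assay compound 3 stands nearest to compound 1 and furthest from compound 2, both within the scatter.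

Compound 4 `O=S(=O)(/C=C/c1ccc(Cl)cn1)c1cccc(F)c1` is not yet measured. It differs from compound 3 by chloro in place of hydrogen on an aromatic carbon, the same change that took compound 1 to compound 2, at the same place. Because that step was a 1.0-fold lower number from compound 1 to compound 2 (0.00 log units; within the scatter), the expected step from compound 3 to compound 4 is a 1.0-fold lower number from compound 3 to compound 4 (0.01 log units; within the scatter). Compound 4 is thus expected to give 1650 nM, with a range from 800 nM to 3400 nM.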

Compound 4, half-maximal effective concentration: 2500 nM
For compound 4 the middle estimate is 1.5-fold (0.18 log units) below the measured one, and the stated range covers the measured number.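

In this assay, chloro in place of hydrogen on an aromatic carbon gives a 1.5-fold higher number from compound 3 to compound 4 (0.17 log units; within the scatter), and the two steps for this change do not differ: the same change on two cores in this assay, a 1.0-fold lower number (0.00 log units; within the scatter) from compound 1 to compound 2 and a 1.5-fold higher number (0.17 log units; within the scatter) from compound 3 to compound 4, 1.5-fold (0.18 log units) apart, within the scatter of two such steps On these two cores, then, the change carries over as a step within the scatter each time. Among the compounds shown here, this does not show that it would behave alike on other cores, since only two pairs bear on it and neither step is large enough to give a clear effect to compare.

The compounds shown leave open whether another group at this place, such as methyl, an amine or a carboxylic acid, would give a step beyond the scatter. They also leave open how chloro behaves on a core without fluoro.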